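Tetrazolylamino amide from an acid chloride on the chromone core

The source may report more compounds than this note shows. Statements on the series, on what has been measured and on what is new or still open speak of the compounds shown alone.

Compound 1 `O=C(Cl)c1ccc2occc(=O)c2c1` is an acid chloride built on a chromone-type core. In a functional assay on cells (Mast cell, Rattus norvegicus) for inhibition, with a stated time of 15 min (a lower number here means that less compound is needed, a higher number that more compound is needed for the effect), compound 1 gave "nd(insoluble)" (no result reported), so it stands nowhere on the scale. Among the measured compounds shown here, the only measured point is compound 2 `O=C(Nc1nc[nH]n1)c1cc(=O)c2ccccc2o1`, an amide on the same kind of core. In this assay compound 2 gives 5 ug/mL.

Compound 3 `O=C(Nc1nnn[nH]1)c1ccc2occc(=O)c2c1` is the amide that comes from compound 1 when ((1H-tetrazol-5-yl)amino in place of chloro on a carbonyl carbon). Compound 1 has no number. The size and direction of the step in this assay cannot be set from it; there is simply nothing to measure against. What remains is compound 2, whose value shows that an amide of this general kind on the chromone core can be active at the low microgram level.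

Compound 3 is therefore expected to land near that mark, at about 5 ug/mL, with a range from 1 ug/mL to 25 ug/mL, the actual value to be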

Compound 3, concentration for half-maximal effect: 0.7 ug/mL
Compound 3: middle estimate off by 7.1-fold (0.85 log units), on the high side; measured number outside the range, below it.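

In this assay, among the compounds shown here, compound 3 gives 0.7 ug/mL while compound 1 has no single number, so no step between compound 1 and compound 3 can be read. Nothing shown here offers an explanation for the value of compound 3. The compounds shown leave open how much the (1H-tetrazol-5-yl)amino group itself contributes to that value.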